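A few compounds are considered here, and "the series" means these few. Any claim that something is new, unique, unknown or untested is made for them only; others in the source may bear on it.

Compound 1 `O=c1c(O)c(-c2ccccc2)oc2cc(OCc3ccccc3[N+](=O)[O-])cc(O)c12`: in an ADME assay on Huh-5-2 cells (Homo sapiens) for cytotoxicity, read by WST assay, with a stated time of 3 days (a higher number here means that more compound is tolerated, a lower number that less compound is tolerated), compound 1 gives 32000 nM.
Compound 2 `Cc1ccccc1COc1cc(O)c2c(=O)c(O)c(-c3ccccc3)oc2c1`: in this assay compound 2 gives 17000 nM.
Compound 3 `Cc1cccc(COc2cc(O)c3c(=O)c(O)c(-c4ccccc4)oc3c2)c1`: in this assay compound 3 gives 35000 nM.

Among these three, compound 1 stands second highest; its nearest neighbour is compound 3, and compound 2 is furthest from it, both of them within the scatter of compound 1. The three compounds share one core and differ only in the group carried on the saturated chain carbon bound to an oxygen on the aromatic ring.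

The unmeasured compound 4 `O=c1c(O)c(-c2ccccc2)oc2cc(OCc3ccc(Cl)cc3)cc(O)c12` keeps that core and changes the same position: 4-chlorophenyl in place of 2-nitrophenyl on a saturated chain carbon bound to an oxygen on an aromatic ring.

Every measured step bears on this change, since each swaps one substituted phenyl for another at the same place. The step of a 1.9-fold lower number from compound 1 to compound 2 (0.27 log units; within the scatter) and the step of a 1.1-fold higher number from compound 1 to compound 3 (0.04 log units; within the scatter) both lie within the scatter, and the step of a 2.1-fold higher number from compound 2 to compound 3 (0.31 log units; beyond the scatter) is only modest. Another substituted phenyl at this position is therefore expected to leave this assay essentially unchanged, with no step beyond the scatter in either direction.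

Compound 4 is expected to give 30000 nM, in a range from 15000 nM to 60000 nM, which would mean a step of a 1.1-fold lower number from compound 1 to compound 4 (0.03 log units; within the scatter).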

Compound 4, half-maximal cytotoxic concentration: > 100000 nM
Compound 4 gave a limit, no number (the forecaster's own chance of this, stated with the estimate: 15%); middle value at least 3.3-fold (0.52 log units) from the limit.
By their numbers in this assay, from the lowest: compounds 2, 1 and 3 (each within the scatter of the next, the first and the last beyond it). At a limit, above all of these: compound 4.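

Compound 4 reads in this assay only as a limit, not as a number: the limit of > 100000 nM in this assay, at which 1 of the 4 values shown sits. This position therefore matters more for tolerance in this assay than compounds 1, 2 and 3 alone showed. 4-chlorophenyl in place of 2-nitrophenyl gives an at least 3.1-fold higher number from compound 1 to compound 4 (0.49 log units; beyond the scatter), while the swaps from the two methylphenyl compounds give an at least 2.8-fold higher number from compound 3 to compound 4 (0.45 log units; beyond the scatter) and an at least 5.8-fold higher number from compound 2 to compound 4 (0.76 log units; beyond the scatter). For the compounds shown here, all three steps lie beyond the scatter and each exceeds any step among the earlier compounds, so a change from one substituted phenyl to another at this carbon is not neutral here, and 4-chlorophenyl stands above 2-nitrophenyl, 2-methylphenyl and 3-methylphenyl alike.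

The compounds shown leave open whether the chlorine itself or its place on the phenyl ring carries these steps, and how far past its limit compound 4 lies. From the compounds shown here alone, what a group without a phenyl ring, such as an amine or a longer chain, would do on this saturated chain carbon also stays open.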